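The source may hold more compounds than are shown below. What is called first, only, known or untested is meant among the compounds shown, and "the series" means these compounds.

Three compounds built on a shared core have numbers in an ADME assay on TZM cells (Homo sapiens) for cytotoxicity, read by CellTiter-Glo, with a stated time of 48 h; on this read-out higher numbers stand for lower toxicity in this test and lower numbers for higher toxicity in this test: compound 1 (`COc1ccc(C2=Cc3ccc([N+](=O)[O-])cc3C(CC(C)=O)N2c2ccc(F)cc2)cc1`) gives 7700 nM, compound 2 (`COc1ccc(C2=Cc3ccc(F)cc3C(CC(=O)CO)N2c2ccc(C)cc2)cc1`) gives 23700 nM, and compound 3 (`COc1ccc(C2=Cc3ccc(F)cc3C(CC(=O)CO)N2c2ccc(Cl)cc2)cc1`) gives 8500 nM. Compound 3 and compound 1 lie within the usual scatter of each other, and both sit well under compound 2.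

Compound 4 (`COc1ccc(C2=Cc3ccc(F)cc3C(CC(=O)CO)N2c2ccc(O)cc2)cc1`) is compound 3 with one change, hydroxy in place of chloro on an aromatic carbon. For the measured compounds named here, only one measured step touches this place, a 2.8-fold lower number from compound 2 to compound 3 (0.45 log units; beyond the scatter), a modest step beyond the scatter, with chloro in place of methyl. Hydroxy itself has no measured example here, so that step offers a guide to size more than to direction. With methyl in compound 2 at 23700 nM, a modest rise is the likelier guess, though a result within the scatter would be no surprise. The expected change is a 1.8-fold higher number from compound 3 to compound 4 (0.25 log units; within the scatter). For compound 4 the estimate is 15000 nM, with an expected range from 6000 nM to 35000 nM.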

Compound 4, half-maximal cytotoxic concentration: 47700 nM
For compound 4 the middle estimate is 3.2-fold (0.50 log units) below the measured one; the measured number lies above the stated range.
By their numbers in this assay, from the lowest: compounds 1 and 3 (each within the scatter of the next); then compounds 2 and 4 (each within the scatter of the next).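

In this assay, the step of a 5.6-fold higher number from compound 3 to compound 4 (0.75 log units; beyond the scatter) lies beyond the scatter, so a third group at this place, para to a large group, shows that the 4-chlorophenyl to 4-hydroxyphenyl change moves the number clearly upward, meaning lower toxicity in this test. The step of a 2.0-fold higher number from compound 2 to compound 4 (0.30 log units; within the scatter) lies within the scatter, so hydroxy and methyl cannot be told apart here, and among compounds 2, 3 and 4 only chloro stands apart, with the lower number. Nothing at hand explains why chloro differs from the other two groups.

From the compounds shown here alone, whether an amine or a methoxy group at this place would match hydroxy and methyl or match chloro remains open. So does whether bromo would follow chloro, and whether the same change would act alike on the core of compound 1.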